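This account rests on a few compounds, and the source may have more. Where it says the series, first, only, none or still open, it means among the compounds named here.

Compound 1 `Cc1nc(S(C)(=O)=O)ccc1Oc1ncnc(OC2CCN(C(=O)O[C@@H](C)CF)CC2)c1F` gives 186 nM in a functional assay on isolated protein for inhibition of Glucose-dependent insulinotropic receptor (Homo sapiens), read by HTRF and cAMP accumulation; a lower number here means that less compound is needed, a higher number that more compound is needed for the effect. Compound 2 `Cc1nc(S(C)(=O)=O)ccc1Oc1ncnc(OC2CCN(C(=O)SC(C)(C)C)CC2)c1F` gives 4.83 nM.

Within the data shown here, compound 2 stands with the lowest of the two numbers; the single measured step, a 39-fold lower number from compound 1 to compound 2 (1.59 log units; beyond the scatter), separates it from compound 1. Compound 3 `Cc1nc(S(C)(=O)=O)ccc1Oc1ncnc(OC2CCN(C(=O)SC3CC3)CC2)c1F` carries cyclopropyl in place of tert-butyl on a sulfur. Among the measured compounds shown here, no measured step touches this place on the sulfur, so the step from compound 1 to compound 2 bears on it only loosely, showing that the group on the carbonyl carbon can move the number greatly. Compound 3 is expected to give 10 nM (range 3 nM to 35 nM), an estimated step of a 2.1-fold higher number from compound 2 to compound 3 (0.32 log units; beyond the scatter).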

Compound 3, half-maximal effective concentration: 24.9 nM
Compound 3: the middle estimate sits 2.5-fold (0.40 log units) below what was measured; the measured number falls inside the stated range.
By their numbers in this assay, from the lowest: compound 2; then compound 3; then compound 1.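

In this assay, the group on the sulfur itself proves to matter, not only the atom joined to the carbonyl carbon: a 5.2-fold higher number from compound 2 to compound 3 (0.71 log units; beyond the scatter), so cyclopropyl does not match tert-butyl at this place. Even so, the sulfur-linked cyclopropyl retains part of the gain over the group in compound 1, with a 7.5-fold lower number from compound 1 to compound 3 (0.87 log units; beyond the scatter). Left open is how an isopropyl group or a longer chain on the sulfur would compare, and whether tert-butyl on an oxygen in place of the sulfur would hold the low number of compound 2. No measured evidence accounts for either step.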